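Compound 2 to compound 3: changing the chain

The compounds below may be only part of what the source reports. "The series", "measured", "known", "first", "only" and "open" are said of these compounds alone.

Compound 1 `NCCCCN(C[C@H]1Cc2ncccc2CN1)[C@H]1CCCc2cccnc21`: 86%
Compound 2 `NC(=O)NCCCCN(C[C@H]1Cc2ncccc2CN1)[C@H]1CCCc2cccnc21`: 32%

In an ADME assay on microsomes from liver (Mus musculus) for metabolic stability, using NADPH, with a stated time of 10 min (a lower number here means that less of the compound is left, a higher number that more of the compound is left), compound 2 holds the lower of the two numbers, at 32%. Compound 3 `NC(=O)NC/C=C/CN(C[C@H]1Cc2ncccc2CN1)[C@H]1CCCc2cccnc21` differs from it in one place: a group of 7 heavy atoms (4 carbon, 2 nitrogen, 1 oxygen; no ring) in place of a group of 7 heavy atoms (4 carbon, 2 nitrogen, 1 oxygen; no ring), on a saturated chain carbon bound to an amine nitrogen. For the measured compounds named here, the only measured step is large, a number 54 percentage points lower from compound 1 to compound 2 (beyond the scatter), but it places carbamoyl in place of hydrogen on an amine nitrogen, which is a different change. Going by the values given here, no measured step therefore speaks directly to this one, and no step beyond the scatter is expected in this assay. The expected change is a number 3 percentage points higher from compound 2 to compound 3 (within the scatter). Compound 3 is estimated at 35%, with an expected range of 15% to 60%.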

Compound 3, percent of the compound remaining: 19%
Compound 3: the middle estimate sits 16 percentage points above what was measured; measured number inside the range.
By their numbers in this assay, from the lowest: compound 3; then compound 2; then compound 1.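

In this assay, the chain at this place, on a saturated chain carbon bound to an amine nitrogen, matters even when the heavy atoms stay the same: replacing 3-ureidopropyl, with 1 double bond, by a group with 2 double bonds gives a number 13 percentage points lower from compound 2 to compound 3 (beyond the scatter) as the result. Compared with the shorter chain, the total change is a number 67 percentage points lower from compound 1 to compound 3 (beyond the scatter) in this series. No measurement here explains either step.

Going by these compounds, it remains open whether the extra double bond alone accounts for the step. A longer chain, or a carboxylic acid at the chain end, could give a different number.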